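Methyl for fluoro on the benzyl ring of compound 1

A few compounds are considered here, and "the series" means these few. Any claim that something is new, unique, unknown or untested is made for them only; others in the source may bear on it.

Among the compounds with values here, compound 1 `CC(C)NC(=O)N1CCN(C(=S)SCc2cn(Cc3ccc(F)cc3)nn2)CC1` gives 1660 nM in a functional assay on MCF7 cells (Homo sapiens) for cytotoxicity, read by MTT assay, with a stated time of 72 h (on this read-out lower numbers stand for stronger inhibition and higher numbers for weaker inhibition), and holds the only number in the set. Compound 2 `O=C(NC1CCCCC1)N1CCN(C(=S)SCc2cn(Cc3ccc(F)cc3)nn2)CC1` sits at the assay limit > 128000 nM (the limit of > 128000 nM in this assay, at which 1 of the 2 values shown sits). The step of an at least 77-fold higher number from compound 1 to compound 2 (1.88 log units; beyond the scatter) concerns the group on the amide-type nitrogen, a different part of the shared core. Compound 3 `Cc1ccc(Cn2cc(CSC(=S)N3CCN(C(=O)NC(C)C)CC3)nn2)cc1` differs from compound 1 by methyl in place of fluoro on an aromatic carbon. Within the data shown here, since the only measured step, an at least 77-fold higher number from compound 1 to compound 2 (1.88 log units; beyond the scatter), lies elsewhere, no shift beyond the scatter is expected for compound 3, no change at the digits printed from compound 1 to compound 3 (within the scatter). Compound 3 is expected near 1660 nM, between 800 nM and 3500 nM.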

Compound 3, half-maximal inhibitory concentration: 4630 nM
Beside the measured number, compound 3's estimate is 2.8-fold (0.45 log units) below it; measured number above the stated range.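

This position on the aromatic ring responds to substitution: in this assay, methyl in place of fluoro gives a 2.8-fold higher number from compound 1 to compound 3 (0.45 log units; beyond the scatter), so 4-methylbenzyl does not simply stand in for 4-fluorobenzyl. The shift remains small compared with the step at the amide-type nitrogen, an at least 77-fold higher number from compound 1 to compound 2 (1.88 log units; beyond the scatter), which is read against an assay limit. No measurement shown bears on why the methyl compound reads higher.

On these data alone, how hydrogen, chloro, methoxy or an amine would read at this position stays open. As far as these compounds go, whether the step carries over to other groups on the amide-type nitrogen also stays open.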